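The source may hold more compounds than are shown below. What is called first, only, known or untested is meant among the compounds shown, and "the series" means these compounds.

Working notes on the series: in a functional assay on PC-3 cells (Homo sapiens) for cytotoxicity, read by WST assay, with a stated time of 72 h (a higher number here means a weaker inhibitor, a lower number a stronger inhibitor), compound 1 `COc1ccc(C2(c3ccc(O)cc3)C(=O)Nc3c2ccc(F)c3F)cc1` gives 2 nM; 2.2 nM; > 1000 nM (3 entries). Compound 2 `O=C1Nc2c(ccc(F)c2F)C1(c1ccc(O)cc1)c1ccc(F)c(F)c1` gives 19 nM, the only number shown for it, with one further entry lacking a single number. Compound 3 `CCCC1(c2ccc(O)cc2)C(=O)Nc2c1ccc(F)c2F` has propyl in place of 3,4-difluorophenyl on a saturated ring carbon. Among the compounds with values here, no measured step covers this change, so the expectation is uncertain. A moderate loss in this assay is expected, estimated as a 6.3-fold higher number from compound 2 to compound 3 (0.80 log units; beyond the scatter). Compound 3 is estimated at 120 nM, with an expected range of 15 nM to 1000 nM.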

Compound 3, half-maximal inhibitory concentration: > 1000 nM
Compound 3 gave a limit, no number; the forecaster's own chance of this, stated with the estimate: 20%; at least 8.3-fold (0.92 log units) between middle value and limit.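

In this assay, propyl in place of 3,4-difluorophenyl on the saturated ring carbon gives an at least 52-fold higher number from compound 2 to compound 3 (1.72 log units; beyond the scatter), the first sign that this position does not accept every group, since compound 1 and compound 2 both carry an aromatic ring there. Compound 3 stands only as a limit, > 1000 nM. The same limit also appears among the entries of compound 1, so a single such reading carries caution: the limit of > 1000 nM in this assay, at which 1 of the 3 values shown sits.

As far as these compounds go, whether the ring itself or merely the size of the group matters stays open. A cyclohexyl group or a longer chain on this carbon would separate the two.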